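This account rests on a few compounds, and the source may have more. Where it says the series, first, only, none or still open, it means among the compounds named here.

Compounds measured so far:
compound 1, `COc1ccc(Nc2ccnc(Nc3ccc(NS(=O)(=O)c4ccc(OC)cc4)cc3)n2)cc1`, 14800 nM
compound 2, `COc1ccc(Nc2ccnc(Nc3ccc(NS(=O)(=O)c4ccc(C)cc4)cc3)n2)cc1`, > 50000 nM
compound 3, `COc1cc(Nc2ccnc(Nc3ccc(NS(=O)(=O)c4ccc(C)cc4)cc3)n2)cc(OC)c1OC`, 46800 nM

In a functional assay on MDA-MB-468 cells (Homo sapiens) for antiproliferative activity, read by MTT assay (a higher number here means a weaker inhibitor, a lower number a stronger inhibitor), compound 1 gives 14800 nM. For compound 2 the result > 50000 nM is a limit of the assay and not a number. Compound 3 gives 46800 nM in this assay and so holds the highest of the two numbers; compound 1, with 14800 nM, sits lower, beyond the scatter.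

Compound 4, `COc1ccc(S(=O)(=O)Nc2ccc(Nc3nccc(Nc4cc(OC)c(OC)c(OC)c4)n3)cc2)cc1`, differs from compound 3 by methoxy in place of methyl on an aromatic carbon. The same change in the opposite direction has been measured: an at least 3.3-fold higher number from compound 1 to compound 2 (0.52 log units; beyond the scatter), where the value of compound 2 is a limit (the limit of > 50000 nM in this assay, at which 1 of the 3 values shown sits). For the measured compounds named here, the other measured step, an at least 1.0-fold lower number from compound 2 to compound 3 (0.02 log units; that floor lies within the scatter), concerns a different part of the molecule and lies within the scatter, so the only guidance is the first step, reversed. A lower number is therefore expected for compound 4, with the step of a 3.6-fold lower number from compound 3 to compound 4 (0.56 log units; beyond the scatter) estimated to mirror that earlier rise in reverse. Compound 4 is accordingly estimated at 13000 nM, with a range of 4000 nM to 40000 nM expected in this assay.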

Compound 4, half-maximal inhibitory concentration: 10300 nM
Compound 4: middle estimate off by 1.3-fold (0.10 log units), on the high side; measured number inside the range.
By their numbers in this assay, from the lowest: compounds 4 and 1 (each within the scatter of the next); then compound 3. At a limit, above all of these: compound 2.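

In this assay, the change from methyl to methoxy, para to a large group on the carbon-only aromatic ring of the sulfonyl part, now has a step with a firm size at both ends: a 4.5-fold lower number from compound 3 to compound 4 (0.66 log units; beyond the scatter). For the compounds shown here, the earlier step on this change ended at the limit of compound 2, so this is the first reading that does not rest on a limit, and the two cores point the same way, with methoxy giving the lower number each time: the same change on two cores in this assay, an at least 3.3-fold higher number (0.52 log units; beyond the scatter) from compound 1 to compound 2 and a 4.5-fold higher number (0.66 log units; beyond the scatter) from compound 4 to compound 3; the limit leaves it open whether they differ. With methoxy held at this position, compound 1 and compound 4 cannot be told apart, a 1.4-fold lower number from compound 1 to compound 4 (0.16 log units; within the scatter), so the swap of 4-methoxyphenyl for 3,4,5-trimethoxyphenyl shows no effect beyond the scatter on either core: the same change on two cores in this assay, an at least 1.0-fold lower number (0.02 log units; that floor lies within the scatter) from compound 2 to compound 3 and a 1.4-fold lower number (0.16 log units; within the scatter) from compound 1 to compound 4; the limit leaves it open whether they differ.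

Only methyl and methoxy are shown at this position, so it remains open whether an amine, a fluorine atom or a longer chain such as ethoxy would give a lower number than methoxy does. The compounds also leave open whether the gain from methoxy would carry over to a core whose other aromatic ring bears something other than methoxy groups, such as a carboxylic acid.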